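This account rests on a few compounds, and the source may have more. Where it says the series, first, only, none or still open, it means among the compounds named here.

Series notes. Compound 1 `O=C(/C=C/c1cccc(Cl)c1)c1nc2ccccc2s1` and compound 2 `O=C(/C=C/c1cccc(Cl)c1)c1nc2ccccc2o1` carry the same chloro-bearing ring on two different cores; the difference between the two cores is not broken down here. Compound 3 `COc1cccc(/C=C/C(=O)c2nc3ccccc3o2)c1` is compound 2 with methoxy in place of chloro on an aromatic carbon. In a functional assay on HepG2 cells (Homo sapiens) for antiproliferative activity, read by MTT assay, with a stated time of 48 h (on this read-out higher numbers stand for weaker inhibition and lower numbers for stronger inhibition), compound 1 gives > 100000 nM, which is a limit of the assay and not a number. Compound 2 gives > 100000 nM, also a limit. Compound 3 gives > 100000 nM, again a limit. The step that the two limits leave unreadable from compound 2 to compound 3 therefore cannot be sized, because of the limit of > 100000 nM in this assay, at which 3 of the 3 values shown sit. Compound 4 `COc1cccc(/C=C/C(=O)c2nc3ccccc3s2)c1` applies the same change to the core of compound 1, (methoxy in place of chloro on an aromatic carbon). The measured step from compound 2 to compound 3 gives no readable size to carry over. The expected step of a number no higher from compound 1 to compound 4 (the limit leaves the size open) rests on compound 1 sitting at the limit > 100000 nM. Compound 4 is estimated at 100000 nM, most probably reported once more as a limit.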

Compound 4, half-maximal inhibitory concentration: > 100000 nM
Compound 4 was reported as a limit (the forecaster's own chance of this, stated with the estimate: 85%); the middle value lies on the limit itself.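

No size can be read for the change from compound 1 to compound 4, as both compounds stand at a limit and not at a number: the limit of > 100000 nM in this assay, at which 4 of the 4 values shown sit.

In this assay the compounds shown leave open how far methoxy in place of chloro moves the read-out on either core.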